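The source may hold more compounds than are shown below. What is called first, only, known or untested is meant among the compounds shown, and "the series" means these compounds.

Measured compounds:
- Compound 2 `CN(C(=O)NC(=O)c1ccc(C(F)(F)F)cc1)c1nc(C(F)(F)F)c(C(=O)N/N=C/c2cccc(C(F)(F)F)c2)s1` — in a functional assay on A549 cells (Homo sapiens) for inhibition, read by MTT assay, with a stated time of 72 h (a lower number here means a stronger inhibitor, a higher number a weaker inhibitor), compound 2 gives 6.66 ug/mL
- Compound 1 `CN(C(=O)NC(=O)c1c(F)cccc1F)c1nc(C(F)(F)F)c(C(=O)N/N=C/c2cccc(C(F)(F)F)c2)s1` — in this assay compound 1 gives 27.6 ug/mL

Going by the values given here, compound 2 stands lowest of the two numbers so far; its nearest neighbour is compound 1, and the step of a 4.1-fold lower number from compound 1 to compound 2 (0.62 log units; beyond the scatter) is the only one in hand, with the replacement of 2,6-difluorophenyl by 4-(trifluoromethyl)phenyl on a carbonyl carbon.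

Compound 3 `CN(C(=O)NC(=O)c1ccccc1F)c1nc(C(F)(F)F)c(C(=O)N/N=C/c2cccc(C(F)(F)F)c2)s1` awaits measurement in this assay. Relative to compound 2 the change is 2-fluorophenyl in place of 4-(trifluoromethyl)phenyl on a carbonyl carbon. This change runs partly back toward compound 1: the trifluoromethyl leaves the ring, and a single fluorine enters, where compound 1 carries two. The step of a 4.1-fold lower number from compound 1 to compound 2 (0.62 log units; beyond the scatter) is the one that bears on it, and it was modest but beyond the scatter. On that basis the number for compound 3 is expected to move upward, most likely by less than the whole of that step, since compound 3 does not fully return to the aryl group of compound 1; the expected step is a 2.3-fold higher number from compound 2 to compound 3 (0.35 log units; beyond the scatter). The estimate for compound 3 in this assay is 15 ug/mL, with a range from 6 ug/mL to 35 ug/mL.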

Compound 3, half-maximal inhibitory concentration: 19.5 ug/mL
For compound 3 the middle estimate is 1.3-fold (0.11 log units) below the measured one; the measured number falls inside the stated range.
By their numbers in this assay, from the lowest: compound 2; then compounds 3 and 1 (each within the scatter of the next).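

Within this assay, taking one fluorine off the aryl group on the carbonyl carbon gives no readable change, a 1.4-fold lower number from compound 1 to compound 3 (0.15 log units; within the scatter), so 2-fluorophenyl and 2,6-difluorophenyl cannot be told apart at this position on these numbers. The replacement of 4-(trifluoromethyl)phenyl by 2-fluorophenyl is a separate matter, a 2.9-fold higher number from compound 2 to compound 3 (0.47 log units; beyond the scatter), which places compound 2 clear of both fluorophenyl compounds and shows that, among the three aryl groups, the step earlier seen from compound 1 to compound 2 is not tied to the second fluorine. No available evidence accounts for these differences, so the numbers stand as observations on this series only.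

As far as these compounds go, the comparison between compound 2 and compound 3 changes both the substituent and where it sits on the ring, so it remains open whether the trifluoromethyl group itself or its placement goes with the lower number. Also open, from the compounds shown here alone, is how a plain phenyl, or a ring carrying a methoxy group, an amine or a carboxylic acid, would compare at this carbonyl carbon in the same assay.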